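This account rests on a few compounds, and the source may have more. Where it says the series, first, only, none or still open, it means among the compounds named here.

Among the compounds with values here, in an assay on AV12 cells for binding affinity to Neuropeptide Y receptor type 1 (Homo sapiens) (a lower number here means a stronger inhibitor, a higher number a weaker inhibitor), compound 3 `Cc1cccc2c1nc(COc1ccc(Cl)cc1)n2CCCC1CCN(Cc2ccccc2)CC1` gives 109 nM, the second highest of the three numbers so far. Compound 1 `Cc1cccc2c1nc(COc1ccc(Cl)cc1)n2CCCC1CCNCC1` gives 335 nM, and compound 2 `CCCN1CCC(CCCn2c(COc3ccc(Cl)cc3)nc3c(C)cccc32)CC1` gives 29 nM. All three share one core and differ only in what sits on the amine nitrogen in the ring: a 12-fold lower number from compound 1 to compound 2 (1.06 log units; beyond the scatter), a 3.1-fold lower number from compound 1 to compound 3 (0.49 log units; beyond the scatter), and a 3.8-fold higher number from compound 2 to compound 3 (0.58 log units; beyond the scatter).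

Compound 4 `Cc1cccc2c1nc(COc1ccc(Cl)cc1)n2CCCC1CCN(CCCC(=O)O)CC1` changes the same position once more, (2-carboxyethyl in place of phenyl on a saturated chain carbon bound to an amine nitrogen in a ring). The three measured steps show that this nitrogen tolerates a range of groups, with the propyl of compound 2 giving the lowest number and the benzyl of compound 3 sitting between it and the bare nitrogen of compound 1. Within the data shown here, none of them carries a carboxylic acid, so no measured step speaks directly to this change. Compound 4 is therefore expected to stay close to compound 3, with a 1.1-fold higher number from compound 3 to compound 4 (0.04 log units; within the scatter) as the estimated step. The estimate for compound 4 in this assay is 120 nM, with a range from 35 nM to 450 nM.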

Compound 4, inhibition constant: 1630 nM
The estimate for compound 4 lay 14-fold (1.13 log units) below the measured number; measured number outside the range, above it.
By their numbers in this assay, from the lowest: compound 2; then compound 3; then compound 1; then compound 4.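

Within the data shown here, in (this assay) the 3-carboxypropyl group is the first group on this amine nitrogen in a ring to give a higher number than the bare nitrogen (a 4.9-fold higher number from compound 1 to compound 4 (0.69 log units; beyond the scatter)), so adding a group here does not always lower the number. The cost is greater against the two groups that lowered it: swapping benzyl for 3-carboxypropyl gives a large step (a 15-fold higher number from compound 3 to compound 4 (1.17 log units; beyond the scatter)), and placing carboxy on the end of the propyl chain gives the largest step in this set (a 56-fold higher number from compound 2 to compound 4 (1.75 log units; beyond the scatter)). No measurement shown explains this loss.

A methyl ester or a primary amide on the same chain would show whether the carboxylic acid itself matters. A carboxylic acid on a shorter or longer chain would show whether its distance from the ring nitrogen matters.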